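Nitro in place of amino across two cores

The compounds below may be only part of what the source reports. "The series", "measured", "known", "first", "only" and "open" are said of these compounds alone.

Compound 1 `COc1ccc2c(/C=C/C(=O)c3cc(N)c(OC)c(OC)c3)c[nH]c2c1` and compound 2 `COc1ccc2c(/C=C/C(=O)c3cc(OC)c(OC)c([N+](=O)[O-])c3)c[nH]c2c1` share one core; compound 3 `COc1cc(C(=O)/C=C/c2cn(C)c3ccccc23)cc(N)c1OC` and compound 4 `COc1cc(C(=O)/C=C/c2cn(C)c3ccccc23)cc([N+](=O)[O-])c1OC` share another. The difference between the two cores is not broken down here. In a functional assay on A2780 cells (Homo sapiens) for antiproliferative activity, read by MTT assay, with a stated time of 48 h (on this read-out lower numbers stand for stronger inhibition and higher numbers for weaker inhibition), compound 1 gives 204 nM, and compound 2 gives 742 nM. The structural change between them is nitro in place of amino on an aromatic carbon and it made a 3.6-fold higher number from compound 1 to compound 2 (0.56 log units; beyond the scatter). Compound 3 gives 441 nM in this assay; against compound 2 this lies within the scatter, against compound 1 beyond it.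

Compound 4 differs from compound 3 by nitro in place of amino on an aromatic carbon. The surroundings of the place are the same, word for word, as for the change from compound 1 to compound 2, so this is the same change, made twice among the compounds shown. For the measured compounds named here, only one measured instance of it exists, and the expectation for compound 4 rests on that instance alone, applied to the value of compound 3.

Going by the values given here, a step from compound 3 to compound 4 in this assay of about the same size as the measured one is expected, because a 3.6-fold higher number from compound 1 to compound 2 (0.56 log units; beyond the scatter) is the only guide available. The expected step is a 3.4-fold higher number from compound 3 to compound 4 (0.53 log units; beyond the scatter). Compound 4 is therefore expected to give about 1500 nM in this assay, with a likely range from 600 nM to 3800 nM, the wider span reflecting that a single pair supports the transfer between cores.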

Compound 4, half-maximal inhibitory concentration: 1890 nM
The estimate for compound 4 lay 1.3-fold (0.10 log units) below the measured number, and the stated range covers the measured number.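

In this assay, nitro in place of amino on the second core gave a 4.3-fold higher number from compound 3 to compound 4 (0.63 log units; beyond the scatter), so in both pairs the amino compound carries the lower number. Set beside the step on the first core, the new step shows that the change carried over with its size intact: the same change on two cores in this assay, a 3.6-fold higher number (0.56 log units; beyond the scatter) from compound 1 to compound 2 and a 4.3-fold higher number (0.63 log units; beyond the scatter) from compound 3 to compound 4, 1.2-fold (0.07 log units) apart, within the scatter of two such steps. This rests on two pairs, a single cell line and one place on the ring, so it shows agreement between these two cores only, says nothing about a core of another kind, and gives no reason for the step.

The compounds shown leave open whether other groups on the same aromatic carbon, such as a hydroxyl, an acetamide or a dimethylamino group, would fall with amino, with nitro or elsewhere. They also leave open what each structural difference between the two cores contributes, as these cores differ in more than one place and a compound carrying only one of those differences would be needed to separate them.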